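Swapping a Benzofuran for a Fluoromethoxyphenyl on the Spiro Core

This account rests on a few compounds, and the source may have more. Where it says the series, first, only, none or still open, it means among the compounds named here.

Compound 1 `O=C1C=CC2(C=C1)OC(=O)C(c1cc3ccccc3o1)=C2c1ccccc1` carries a 1-benzofuran-2-yl group on the double-bonded carbon of its five-membered ring. In an ADME assay on MEpiC cells (Homo sapiens) for antiproliferative activity, read by MTT assay, with a stated time of 48 h (on this read-out higher numbers stand for weaker inhibition and lower numbers for stronger inhibition), compound 1 gives 66600 nM, the highest of the two numbers measured, so it is the weaker inhibitor of the pair. Compound 2 `COc1cc(C2=C(c3ccccc3)C3(C=CC(=O)C=C3)OC2=O)cc(OC)c1OC` gives 6610 nM in this assay, a lower number, which lies beyond the usual scatter. Compound 3 `COc1ccc(F)cc1C1=C(c2ccccc2)C2(C=CC(=O)C=C2)OC1=O` is the next structure to be tested; it differs from compound 1 by 5-fluoro-2-methoxyphenyl in place of 1-benzofuran-2-yl on a double-bonded ring carbon. Within the data shown here, no directly comparable step has been measured, so the direction of the change is uncertain. Given that compound 2 with a methoxy-bearing phenyl gives 6610 nM, a moderate move toward stronger inhibition is expected, but smaller than that gap. Compound 3 is expected to reach about 20000 nM in this assay, within a range of 5000 nM to 70000 nM, an estimated step of a 3.3-fold lower number from compound 1 to compound 3 (0.52 log units; beyond the scatter).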

Compound 3, half-maximal inhibitory concentration: 13500 nM
For compound 3 the middle estimate is 1.5-fold (0.17 log units) above the measured one; the range from low to high includes it.
By their numbers in this assay, from the lowest: compound 2; then compound 3; then compound 1.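

Putting 5-fluoro-2-methoxyphenyl in place of 1-benzofuran-2-yl on this double-bonded ring carbon gives a 4.9-fold lower number from compound 1 to compound 3 (0.69 log units; beyond the scatter) in this assay, so with the rest of the core unchanged, the number responds to the group at this position. The two groups have the same counts of heavy atoms, hydrogen-bond donors and hydrogen-bond acceptors, so those counts alone do not settle the number here; they differ instead in their rings and in the fluorine. Nothing measured here explains the shift.

This single swap removes the fused ring system and adds the fluorine and the methoxy together, so the contribution of each part cannot be separated. Going by these compounds, how an amine or a carboxylic acid on the same ring carbon would read in this assay also remains open.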